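Three aryl groups, one value, and a phenyl analogue

The source may hold more compounds than are shown below. What is called first, only, known or untested is meant among the compounds shown, and "the series" means these compounds.

Compound 1, `O=c1oc2ccccc2c2nc3c(ccc4cc[nH]c43)c(-c3cccnc3Cl)c12`, gives 70700 nM.
Compound 2, `O=c1oc2ccccc2c2nc3c(ccc4cc[nH]c43)c(-c3cccc(Br)c3)c12`, gives 70700 nM.
Compound 3, `Cc1ccc(-c2c3ccc4cc[nH]c4c3nc3c2c(=O)oc2ccccc23)cc1`, gives 70700 nM.

The three compounds share one core and differ only in the aryl group attached to it. In a functional assay on B16-F10 cells (Mus musculus) for cytotoxicity (a lower number here means a stronger inhibitor, a higher number a weaker inhibitor), compound 1 stands level with compounds 2 and 3: the step from compound 1 to compound 2 is no change at the digits printed from compound 1 to compound 2 (within the scatter), the step from compound 1 to compound 3 is no change at the digits printed from compound 1 to compound 3 (within the scatter), and the step from compound 2 to compound 3 is no change at the digits printed from compound 2 to compound 3 (within the scatter). Three rather different aryl groups thus give the same read-out within the usual scatter.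

Compound 4, `O=c1oc2ccccc2c2nc3c(ccc4cc[nH]c43)c(-c3ccccc3)c12`, is not yet measured. It differs from compound 1 as follows: phenyl in place of 2-chloropyridin-3-yl on an aromatic carbon. This is again a change of the aryl group alone, of the same kind as the three steps already seen, each of which stayed within the scatter. No step among the measured compounds gives reason to expect the phenyl analogue to move the number either way.

Compound 4 is therefore expected to give 70700 nM in this assay, with a range from 35000 nM to 141000 nM. The step expected from this estimate is no change at the digits printed from compound 1 to compound 4 (within the scatter), that is, no change beyond the scatter.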

Compound 4, half-maximal inhibitory concentration: 70700 nM
Compound 4: middle estimate and measured number agree at the digits printed; the measured number falls inside the stated range.
By their numbers in this assay, from the lowest: compounds 1, 2, 3 and 4 (each within the scatter of the next).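

Within the data shown here, compound 4 supplies the plain phenyl reference that the earlier compounds lacked, so each substituent can now be judged against the same ring without it. In this assay, hydrogen in place of methyl gives no change at the digits printed from compound 3 to compound 4 (within the scatter), and hydrogen in place of bromo gives no change at the digits printed from compound 2 to compound 4 (within the scatter), so neither the 4-methyl nor the 3-bromo group shifts the number beyond the scatter in these compounds. Phenyl in place of 2-chloropyridin-3-yl removes the ring nitrogen and the chlorine in a single change and gives no change at the digits printed from compound 1 to compound 4 (within the scatter), so taken together, their removal leaves the read-out unmoved here, although this step cannot separate the two atoms; no accompanying measurement offers an explanation for this flat result.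

Every group shown at this position is a six-membered aromatic ring, so it remains open whether an amine, a carboxylic acid or a longer alkyl chain placed there would move the number. All four compounds also share the same core, so what the core itself contributes to the value of compound 4, 70700 nM, cannot be read from them.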